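The compounds below may be only part of what the source reports. "The series", "measured", "known", "first", "only" and "open" are said of these compounds alone.

Compound 1 `COc1ccc(/C=C/c2cc(C)no2)cc1OC`: > 100000 nM
Compound 2 `COc1ccc(/C=C/c2cc(C)no2)cc1`: > 100000 nM

In a functional assay on PC-3 cells (Homo sapiens) for cytotoxicity, read by MTT assay, with a stated time of 72 h (a higher number here means a weaker inhibitor, a lower number a stronger inhibitor), compound 1 gives > 100000 nM, which is a limit and not a number. Compound 2 gives > 100000 nM, which is also a limit. This leaves compound 1 at the limit of > 100000 nM in this assay, at which 2 of the 2 values shown sit.

Compound 3 `COc1ccc(/C=C/c2cc(C)n[nH]2)cc1OC` keeps the core of compound 1 but differs in one group: 3-methyl-1H-pyrazol-5-yl in place of 3-methyl-1,2-oxazol-5-yl on a double-bonded chain carbon bound to a double-bonded chain carbon. The swap sits on a double-bonded chain carbon bound to a double-bonded chain carbon.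

Going by the values given here, the only measured step, a step that the two limits leave unreadable from compound 1 to compound 2, puts hydrogen in place of methoxy on an aromatic carbon. It is a different change and has no readable size to carry over. Any readable step in this assay is therefore expected to be modest and toward a lower number, but compound 3 may well stay at the limit. The estimated step is an at least 1.6-fold lower number from compound 1 to compound 3 (0.22 log units; that floor lies within the scatter). For compound 3 the expected value is 60000 nM, with an estimated range from 15000 nM to 100000 nM.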

Compound 3, half-maximal inhibitory concentration: 12600 nM
Beside the measured number, compound 3's estimate is 4.8-fold (0.68 log units) above it; measured number outside the range, below it.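

Putting 3-methyl-1H-pyrazol-5-yl in place of 3-methyl-1,2-oxazol-5-yl on this double-bonded chain carbon moves the result in this assay off the limit and gives a readable change (an at least 7.9-fold lower number from compound 1 to compound 3 (0.89 log units; beyond the scatter)). So this place responds to a change of group, something the unreadable step between compound 1 and compound 2 could not show. Going by these compounds alone, compound 3 is also the only compound here with an actual number, and the other two remain limits: the limit of > 100000 nM in this assay, at which 2 of the 3 values shown sit.

The swap brings in 1 hydrogen-bond donor where there were 0, but a single pair cannot show whether that count, or something else about the new group, accounts for the change. Also open, on these data alone, are what the methoxy groups contribute alongside 3-methyl-1H-pyrazol-5-yl and what an amine in place of its methyl group would do.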